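The source may report more compounds than this note shows. Statements on the series, on what has been measured and on what is new or still open speak of the compounds shown alone.

Of the compounds shown here, two of a shared core have been measured in an assay on HEK293 cells for inhibition of Voltage-dependent T-type calcium channel subunit alpha-1H (Homo sapiens), read by FLIPR and calcium flux, with a stated time of 3 min; a higher number here means a weaker inhibitor, a lower number a stronger inhibitor. Compound 1, `CS(=O)(=O)c1ccc(C2CC(c3ccncc3)=NN2C(=O)Nc2ccc(F)cc2)cc1`, gives 410 nM in this assay. Compound 2, `COCC1(c2ccc(C)cc2)CC(c2ccccc2)=NN1C(=O)Nc1ccc(F)cc1`, gives 350 nM in this assay, the lowest of the two numbers; the gap to compound 1 lies within the scatter, so the two cannot be ranked against each other.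

Compound 3, `Cc1ccc(C2(CCN(C)C)CC(c3ccccc3)=NN2C(=O)Nc2ccc(F)cc2)cc1`, is not yet measured. It differs from compound 2 in one place: (dimethylamino)methyl in place of methoxy on a saturated chain carbon bound to a saturated ring carbon. Among the measured compounds shown here, no pair of measured compounds shows this change, so nothing in the numbers so far points to a direction. Compound 3 is therefore expected to stay close to compound 2, with the step of a 1.2-fold lower number from compound 2 to compound 3 (0.07 log units; within the scatter) expected to fall within the scatter. The estimate for compound 3 in this assay is 300 nM, with a range from 100 nM to 900 nM.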

Compound 3, half-maximal inhibitory concentration: 240 nM
Estimate against measurement, compound 3: 1.3-fold (0.10 log units) above; the range from low to high includes it.
By their numbers in this assay, from the lowest: compounds 3, 2 and 1 (each within the scatter of the next).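

In this assay, among the compounds shown here, (dimethylamino)methyl in place of methoxy on a saturated chain carbon bound to a saturated ring carbon gives a 1.5-fold lower number from compound 2 to compound 3 (0.16 log units; within the scatter), the first step that can be read at this position. Methoxymethyl and 2-(dimethylamino)ethyl therefore cannot be told apart here, so exchanging the oxygen-bearing chain for a longer nitrogen-bearing one leaves no readable mark on the number. Nothing shown offers a measured explanation for this result.

As far as these compounds go, whether a carboxylic acid, a morpholine or a still longer chain on this carbon would also stay within the scatter of compound 2 remains open. This change rests on a single pair of compounds in one assay, so whether it would read the same on another substitution of the shared core is also unknown.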